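The compounds below may be only part of what the source reports. "The series", "measured", "known", "first", "only" and "open" are said of these compounds alone.

Measured compounds:
- compound 1, `CC(C)C(Cc1ncc[nH]1)c1ccc(-c2ccc3cccc(F)c3c2)[nH]c1=O`, in an ADME assay on microsomes from liver (Homo sapiens) for metabolic stability (a higher number here means that the compound lasts longer, a lower number that the compound disappears faster), gives 0.106 h
- compound 3, `CCC(CC)(c1nnc[nH]1)c1ccc(-c2ccc3cccc(F)c3c2)[nH]c1=O`, gives 1.19 h
- compound 2, `CCn1ncc2c(F)cc(-c3ccc(C(CC)(CC)c4nnc(C)[nH]4)c(=O)[nH]3)cc21`, gives only a limit, > 3 h

Among the measured compounds shown here, compound 1 stands lowest of the two numbers known in this assay. Its nearest neighbour is compound 3, whose value lies well above it, a gap beyond the usual scatter of repeated measurements. The value of compound 2 is a limit of the assay and not a number (the limit of > 3 h in this assay, at which 1 of the 3 values shown sits).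

The account now follows the step from compound 1 to compound 4, `CC(C)C(c1cnc(N)s1)c1ccc(-c2ccc3cccc(F)c3c2)[nH]c1=O`, which has not yet been measured. The two structures differ in one place: 2-amino-1,3-thiazol-5-yl in place of (1H-imidazol-2-yl)methyl on a saturated chain carbon bound to an aromatic carbon and a saturated chain carbon.

For the measured compounds named here, no step between measured compounds is known that would show how this change moves the half-life, so the expectation rests on compound 1 alone. The step from compound 1 to compound 4 is expected to be small, with no clear direction, and probably not beyond the scatter. Compound 4 is therefore estimated to give 0.15 h, in the range 0.05 h to 0.5 h. Such an expected step, a 1.4-fold higher number from compound 1 to compound 4 (0.15 log units; within the scatter), would leave compound 4 close to compound 1 and still well short of compound 3.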

Compound 4, half-life: 0.178 h
Estimate against measurement, compound 4: 1.2-fold (0.07 log units) below, and the stated range covers the measured number.
By their numbers in this assay, from the lowest: compounds 1 and 4 (each within the scatter of the next); then compound 3. At a limit, above all of these: compound 2.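

Among the compounds shown here, replacing (1H-imidazol-2-yl)methyl with 2-amino-1,3-thiazol-5-yl on a saturated chain carbon bound to an aromatic carbon and a saturated chain carbon gives a 1.7-fold higher number from compound 1 to compound 4 (0.23 log units; within the scatter) in this assay and provides the first comparison of compounds that differ in one place. At this position, the two groups therefore cannot be told apart by half-life, even though sulfur enters with the 2-amino-1,3-thiazol-5-yl group and the count of hydrogen-bond acceptors differs between them. Nothing among the measurements shown accounts for this outcome or connects either group to the half-life.

The compounds shown leave open whether a carboxylic acid, a simple amine or a longer chain in this same place would separate itself from these two groups in this assay. As far as these compounds go, the steps from compound 1 or compound 4 to compound 2 and compound 3 cannot be read, since those compounds differ from them in more than one place, so the effect of this exchange on the other compounds also remains unknown.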